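The source may report more compounds than this note shows. Statements on the series, on what has been measured and on what is new or still open speak of the compounds shown alone.

In a functional assay on HepG2 cells (Homo sapiens) for cytotoxicity, read by MTT assay (a lower number here means a stronger inhibitor, a higher number a weaker inhibitor), compound 3 (`C=C1C(=O)[C@]23C[C@@]1(F)CC[C@H]2[C@@]12C=CC(=O)[C@](C)(C(=O)O1)[C@H]2[C@@H]3C(=O)OCc1ccccc1`) gives 44100 nM, at the high end of the three numbers and within the scatter of compound 2 (`C=C1C(=O)[C@]23C[C@@]1(F)CC[C@H]2[C@@]12C=CC(=O)[C@](C)(C(=O)O1)[C@H]2[C@@H]3C(=O)OC`) at 40600 nM. Compound 1 (`C=C1C(=O)[C@]23C[C@@]1(Cl)CC[C@H]2[C@@]12C=CC(=O)[C@](C)(C(=O)O1)[C@H]2[C@@H]3C(=O)OCc1ccccc1`) gives a lower number, 17900 nM. Compound 4 (`C=C1C(=O)[C@]23C[C@@]1(I)CC[C@H]2[C@@]12C=CC(=O)[C@](C)(C(=O)O1)[C@H]2[C@@H]3C(=O)OCc1ccccc1`) differs from compound 3 by one change: iodo in place of fluoro on a saturated ring carbon. The nearest measured evidence is a 2.5-fold higher number from compound 1 to compound 3 (0.39 log units; beyond the scatter), a modest halogen swap at this same carbon. The other measured step, a 1.1-fold higher number from compound 2 to compound 3 (0.04 log units; within the scatter), lies elsewhere and says little here. Going by the values given here, no iodo compound has been measured, so the chloro comparison is only a rough guide. A modest step is expected in this assay, namely a 2.8-fold lower number from compound 3 to compound 4 (0.44 log units; beyond the scatter). Compound 4 is estimated at 16000 nM, with an expected range of 7000 nM to 36000 nM.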

Compound 4, half-maximal inhibitory concentration: 69500 nM
Estimate against measurement, compound 4: 4.3-fold (0.64 log units) below; the measured number lies above the stated range.
By their numbers in this assay, from the lowest: compound 1; then compounds 2, 3 and 4 (each within the scatter of the next).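

In this assay putting iodo in place of fluoro on this saturated ring carbon gives a 1.6-fold higher number from compound 3 to compound 4 (0.20 log units; within the scatter) while iodo in place of chloro gives a 3.9-fold higher number from compound 1 to compound 4 (0.59 log units; beyond the scatter) at the same carbon. Of the three halogens shown, only chloro in compound 1 stands apart from the others, so the numbers do not follow the order of the halogens. No evidence here explains this. From the compounds shown here alone, whether bromo would sit with chloro or with the other two remains open, as does the effect of an amine or a hydroxyl on this carbon.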